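Fluorine count and chromatographic lipophilicity in a quinoline amide series

A few compounds are considered here, and "the series" means these few. Any claim that something is new, unique, unknown or untested is made for them only; others in the source may bear on it.

The three compounds measured here share one core and differ only in the aromatic ring on the amide nitrogen. In a physicochemical assay for lipophilicity, read by HPLC, in phosphate buffer, measured as chromatographic lipophilicity, at pH 7.4 (on this read-out higher numbers stand for higher lipophilicity and lower numbers for lower lipophilicity), compound 1 `COc1ccc2nc(C)cc(OCC(=O)Nc3ccccc3)c2c1` gives 4.28, compound 2 `COc1ccc2nc(C)cc(OCC(=O)Nc3cccc(C)c3)c2c1` gives 4.83, and compound 3 `COc1ccc2nc(C)cc(OCC(=O)Nc3cc(F)cc(F)c3)c2c1` gives 5.13, the highest of the three. The step of a number 0.55 log units higher from compound 1 to compound 2 (beyond the scatter) is modest, and a number 0.85 log units higher from compound 1 to compound 3 (beyond the scatter) is also modest, while a number 0.30 log units higher from compound 2 to compound 3 (within the scatter) stays within the scatter.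

Compound 4 `COc1ccc2nc(C)cc(OCC(=O)Nc3ccc(F)cc3)c2c1` is not yet measured. It differs from compound 3 by 4-fluorophenyl in place of 3,5-difluorophenyl on an amide-type nitrogen. The step from compound 1 to compound 3 covers the addition of both fluorine atoms, and compound 4 carries only part of that change. The expected result for compound 4 in this assay is therefore a number below compound 3 but above compound 1, with an expected step of a number 0.43 log units lower from compound 3 to compound 4 (beyond the scatter). For compound 4 the estimated value is 4.7, with a range from 4.4 to 5.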

Compound 4, distribution coefficient: 4.49
Compound 4: the middle estimate sits 0.21 log units above what was measured; the measured number falls inside the stated range.
By their numbers in this assay, from the lowest: compounds 1 and 4 (each within the scatter of the next); then compounds 2 and 3 (each within the scatter of the next).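

In this assay the 4-fluorophenyl group gives a number 0.21 log units higher from compound 1 to compound 4 (within the scatter) and so cannot be told apart from plain phenyl on this amide-type nitrogen, whereas the 3,5-difluorophenyl group stands clear of the 4-fluorophenyl group, with a number 0.64 log units lower from compound 3 to compound 4 (beyond the scatter) on the same nitrogen. The 4-fluorophenyl group also differs from 3-methylphenyl, with a number 0.34 log units lower from compound 2 to compound 4 (beyond the scatter) in this comparison, so among these four compounds a single fluorine does not match the effect of either the methyl or the pair of fluorines. No measurement shown here explains these differences. The two fluorinated rings differ in both the number of fluorine atoms and where they sit, and these compounds do not separate the two. In this assay, from the compounds shown here alone, the effect of an amine or a carboxylic acid on the phenyl ring also remains open.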